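The compounds below may be only part of what the source reports. "The series", "measured", "known", "first", "only" and "open" are said of these compounds alone.

Working notes on the series.

Compound 1 `CC1=C(N2CC2)C(=O)C(CCC(=O)N(C)C)=C(N2CC2)C1=O` is measured in a functional assay on L1210 cells (Mus musculus), with a stated time of 1 days (a lower number here means a less potent compound, a higher number a more potent compound, by a factor of ten per unit of this negative logarithm), and gives 4.84. Among the three compounds measured so far it holds the second highest number. Compound 3 `COCCOC(COC(N)=O)C1=C(N2CC2)C(=O)C(C)=C(N2CC2)C1=O` gives 4.96, and the gap between compound 1 and compound 3 lies within the scatter, so no order between these two is claimed. Compound 2 `CC(C)C1=C(N2CC2)C(=O)C(C(C)C)=C(N2CC2)C1=O` gives 4.14, a number clearly lower than that of compound 1 and beyond the scatter.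

Compound 4 `CC1=C(N2CC2)C(=O)C(Cc2ccccc2)=C(N2CC2)C1=O` is not yet measured. It differs from compound 1 in one place: phenyl in place of (dimethylcarbamoyl)methyl on a saturated chain carbon bound to a double-bonded ring carbon. The same change, read one bond further out, exchanges 2-(dimethylcarbamoyl)ethyl for benzyl on the shared core.

Among the measured compounds shown here, no pair of measured compounds differing in one place is available, so the size of this step cannot be read from measured data. The three measured numbers span a modest range, and the lowest of them belongs to compound 2, which carries two isopropyl groups rather than the substituents of compound 1. For compound 4 the expected step of a number 0.14 log units lower from compound 1 to compound 4 (within the scatter) is small and within the scatter, with a slight lean downward. Compound 4 is therefore expected to give 4.7, with a range from 4.1 to 5.3.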

Compound 4, logarithm of the reciprocal of the active concentration, log(1/C): 4.26
The estimate for compound 4 lay 0.44 log units above the measured number, within the range that was stated.
By their numbers in this assay, from the lowest: compounds 2 and 4 (each within the scatter of the next); then compounds 1 and 3 (each within the scatter of the next).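

Among the compounds shown here, this is the first step that can be read: in this assay, phenyl in place of (dimethylcarbamoyl)methyl on a saturated chain carbon bound to a double-bonded ring carbon gives a number 0.58 log units lower from compound 1 to compound 4 (beyond the scatter) on the shared core. The number therefore responds to what this chain carries, even though the two groups have the same heavy-atom count, and 2-(dimethylcarbamoyl)ethyl cannot be exchanged for benzyl without a loss here. No measurement bears on why the step arises.

A single pair cannot separate the loss of the amide from the arrival of the aromatic ring. A cyclohexyl group in place of the phenyl, or a carboxylic acid in place of the dimethylamide, would be needed to tell these apart.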